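Piperazine ester series: cytotoxicity on MDCK cells

This account rests on a few compounds, and the source may have more. Where it says the series, first, only, none or still open, it means among the compounds named here.

Measured so far:
compound 1, `CC1(C)[C@H]2CC[C@]1(C)[C@H](OC(=O)CCN1CCNCC1)C2`: 12600 nM
compound 2, `CCN1CCN(CC(=O)O[C@@H]2C[C@@H]3CC[C@@]2(C)C3(C)C)CC1`: 100000 nM

In an ADME assay on MDCK cells (Canis lupus familiaris) for cytotoxicity, read by MTT assay, with a stated time of 48 h (on this read-out lower numbers stand for higher toxicity in this test and higher numbers for lower toxicity in this test), compound 1 gives 12600 nM. In this assay compound 2 gives 100000 nM, the highest of the two numbers, with compound 1 the nearer neighbour; the two values differ by more than the usual scatter. Among the measured compounds shown here, no pair differing in a single place has been measured, so no measured step is available.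

Compound 3, `CN1CCN(CC(=O)O[C@@H]2C[C@@H]3CC[C@@]2(C)C3(C)C)CC1`, has not yet been tested in this assay. It differs from compound 2 in one place: hydrogen in place of methyl on a saturated chain carbon bound to an amine nitrogen in a ring. For the measured compounds named here, the change is small, and only two compounds give context. The step of a 1.3-fold lower number from compound 2 to compound 3 (0.10 log units; within the scatter) is expected to be within the scatter, with no clear direction. On that basis compound 3 is estimated at 80000 nM, within a range of 30000 nM to 200000 nM.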

Compound 3, half-maximal cytotoxic concentration: 103000 nM
For compound 3 the middle estimate is 1.3-fold (0.11 log units) below the measured one, within the range that was stated.
By their numbers in this assay, from the lowest: compound 1; then compounds 2 and 3 (each within the scatter of the next).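

At this place, hydrogen in place of methyl on a saturated chain carbon bound to an amine nitrogen in a ring gives a 1.0-fold higher number from compound 2 to compound 3 (0.01 log units; within the scatter) in this assay, so ethyl to methyl does not move the read-out beyond the scatter. Among the compounds shown here, by contrast, 4-methylpiperazin-1-yl in place of (piperazin-1-yl)methyl on a saturated chain carbon bound to a carbonyl carbon gives an 8.2-fold higher number from compound 1 to compound 3 (0.91 log units; beyond the scatter) on the same read-out, the only step so far that lies beyond the scatter. No measured property is available to account for either step.

The compounds shown leave open whether a longer chain or a benzyl group at the amine nitrogen would stay within the scatter of compound 3. A carboxylic acid on that chain is also an open case.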